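Pyrazolo-fused lactam series: aryl in place of alkyl

This account rests on a few compounds, and the source may have more. Where it says the series, first, only, none or still open, it means among the compounds named here.

Measured so far:
compound 1 `Cc1cc2[nH]nc(N)c2c(=O)[nH]1` — 8%
compound 2 `Cc1cc2nn(-c3ccccc3)c(N)c2c(=O)[nH]1` — 1%
compound 3 `CC(C)(C)c1cc2nn(-c3ccccc3)c(N)c2c(=O)[nH]1` — 3%

All three values come from an assay on isolated protein for inhibition of RAC-beta serine/threonine-protein kinase (Homo sapiens), read by mobility shift assay, tested at 30 uM; a lower number here means less inhibition, a higher number more inhibition at the concentration tested (going by the name of the read-out). Compound 3 sits within the usual scatter of both compound 2 and compound 1; none of the three numbers is separated from another beyond the scatter, so no order among them can be read.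

Compound 4 `Nc1c2c(=O)[nH]c(-c3ccccc3)cc2nn1-c1ccccc1` is the next member. Change from compound 3: phenyl in place of tert-butyl on an aromatic carbon. Within the data shown here, the only measured step at that carbon is a number 2 percentage points higher from compound 2 to compound 3 (within the scatter), which was within the scatter. Nothing measured covers an aromatic group at this position, so no step beyond the scatter is expected in this assay. Compound 4 is estimated at 4%, range -6% to 14%, an expected step of a number 1 percentage points higher from compound 3 to compound 4 (within the scatter).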

Compound 4, a percentage reported as inhibition, at one concentration (the size of the read-out at that concentration, not a potency): -1%
Compound 4: middle estimate off by 5 percentage points, on the high side; the range from low to high includes it.
By their numbers in this assay, from the lowest: compounds 4, 2, 3 and 1 (each within the scatter of the next).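

Phenyl on the aromatic carbon next to the ring nitrogen brings the first aromatic ring to this position, and in this assay the change from tert-butyl gives a number 4 percentage points lower from compound 3 to compound 4 (within the scatter), while the change from methyl gives a number 2 percentage points lower from compound 2 to compound 4 (within the scatter). Methyl, tert-butyl and phenyl therefore cannot be told apart at this carbon, despite the added ring and the larger group. No supporting data bear on this result.

Going by these compounds, whether an amine or a carboxylic acid at this carbon would move the read-out beyond the scatter remains open.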